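This account rests on a few compounds, and the source may have more. Where it says the series, first, only, none or still open, it means among the compounds named here.

Among the measured compounds shown here, in a physicochemical assay for solubility, at pH 7.4 (a lower number here means a less soluble compound, a higher number a more soluble compound), three compounds have numbers so far. Compound 1 (`Cc1cc(NC(=O)Nc2ccccc2OC(F)(F)F)c2ccccc2n1`) gives 4600 nM and compound 3 (`Cc1cc(NC(=O)Nc2ccc(N)cc2)c2ccccc2n1`) gives 18500 nM on the same read-out. Compound 2 (`COC(=O)c1cccc(NC(=O)Nc2cc(C)nc3ccccc23)c1`) stands lowest at 600 nM with both gaps to the other two beyond the usual scatter of repeated measurements. Compound 1 is its nearest neighbour on these numbers and compound 3 its furthest.

Compound 4 (`Cc1cc(NC(=O)Nc2cccc(C(C)(C)C)c2)c2ccccc2n1`) has not yet been measured. It differs from compound 2 in one place, with tert-butyl in place of methoxycarbonyl on an aromatic carbon, meta to a large group (tert-butyl in place of methoxycarbonyl on an aromatic carbon). For the measured compounds named here, no two measured compounds differ in one place only, so the data hold no direct guide to this swap. The expectation therefore starts from compound 2 at 600 nM and has little else to lean on. A small fall is expected in this assay with an estimated step of a 1.7-fold lower number from compound 2 to compound 4 (0.23 log units; within the scatter) that is not clearly beyond the scatter. A result on the higher side cannot be ruled out, so the range is kept wide. Compound 4 is expected at 350 nM with an estimated range from 100 nM to 1500 nM as a rough guide.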

Compound 4, solubility: 34700 nM
Compound 4: middle estimate off by 99-fold (2.00 log units), on the low side; measured number above the stated range.
By their numbers in this assay, from the lowest: compound 2; then compound 1; then compounds 3 and 4 (each within the scatter of the next).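

In this assay, among the compounds shown here, the swap of methoxycarbonyl for tert-butyl on an aromatic carbon, meta to a large group, gives a 58-fold higher number from compound 2 to compound 4 (1.76 log units; beyond the scatter), and this is the first comparison in the set in which only one place changes. It shows that this position is far from indifferent to the group it carries: the two groups have the same count of 4 heavy atoms, neither has a ring and neither has a net charge, yet the numbers lie far apart. The higher number goes with tert-butyl, which is all carbon with no hydrogen-bond acceptors, but nothing measured here accounts for the size of the step.

As far as these compounds go, with a single step at this position, it remains open whether the rise belongs to the arrival of tert-butyl or to the departure of methoxycarbonyl, and whether the same swap would give a step of similar size elsewhere on the ring. A carboxylic acid or a nitrile in this same place would help to separate those readings, as would a smaller all-carbon group such as an ethyl chain.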